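Replacing the 4-fluorophenyl end of compound 2

The compounds below may be only part of what the source reports. "The series", "measured", "known", "first", "only" and "open" are said of these compounds alone.

Compound 1 (`COc1ccc(/C=C/C(=O)NCCCC(C)Nc2cc(OC)cc3cccnc23)cc1`): > 100 ug/mL (a limit)
Compound 2 (`COc1cc(NC(C)CCCNC(=O)Nc2ccc(F)cc2)c2ncccc2c1`): 9.3 ug/mL

Within the data shown here, in an ADME assay on L6 cells (Rattus norvegicus) for cytotoxicity, read by resazurin assay, with a stated time of 70 h (on this read-out higher numbers stand for weaker inhibition and lower numbers for stronger inhibition), compound 2 gives 9.3 ug/mL as the only actual number so far. Compound 1 gives > 100 ug/mL as a limit of the assay and not a number.

Compound 3 (`COc1cc(NC(C)CCCNC(=O)NNC(=O)Nc2cccc(Cl)c2)c2ncccc2c1`) is still unmeasured and shares the core of compound 2. The change is ((3-chlorophenyl)carbamoyl)amino in place of 4-fluorophenyl on an amide-type nitrogen and amounts to ((3-chlorophenyl)carbamoyl)amino in place of 4-fluorophenyl on an amide-type nitrogen.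

Among the measured compounds shown here, only one measured step bears on this end of the molecule. That step, an at least 10-fold lower number from compound 1 to compound 2 (1.03 log units; beyond the scatter) is large and beyond the scatter, and it brought in the (4-fluorophenyl)amino group. As far as these compounds go, its true size stays open because of the limit of > 100 ug/mL in this assay, at which 1 of the 2 values shown sits, and it involves a different swap, so it is only a loose guide.

Compound 3 loses the 4-fluorophenyl group but keeps an aromatic ring, so a moderate move towards a higher number, meaning weaker inhibition, is expected. The expected change is a 2.2-fold higher number from compound 2 to compound 3 (0.33 log units; beyond the scatter) in this assay and may not clearly exceed the scatter. For compound 3 the estimate is 20 ug/mL with an expected range from 5 ug/mL to 80 ug/mL on this read-out.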

Compound 3, half-maximal inhibitory concentration: 27.6 ug/mL
Estimate against measurement, compound 3: 1.4-fold (0.14 log units) below; the measured number falls inside the stated range.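

In this assay, among these compounds, the swap at this amide-type nitrogen gives a 3.0-fold higher number from compound 2 to compound 3 (0.47 log units; beyond the scatter), which is the first step at this end of the molecule with an actual number on both sides. It shows that the 4-fluorophenyl group can give way to the larger ((3-chlorophenyl)carbamoyl)amino group, which also keeps an aromatic ring and brings hydrogen-bond donors, at a modest cost in inhibition of the L6 cells. Compound 1 gives only a limit and not a number, so the earlier step into compound 2 has no known size to set beside this one: the limit of > 100 ug/mL in this assay, at which 1 of the 3 values shown sits.

The step changes two things at once, the stretch of atoms leading to the ring and the halogen on that ring, so the compounds shown leave open how much of the move belongs to each. They also leave open how this nitrogen behaves with a group that has no aromatic ring at all, such as a simple amine or a carboxylic acid on a short chain, and whether such a group would raise or lower the number.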